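Deazapurine nucleosides: removing the amino group from compound 3

A few compounds are considered here, and "the series" means these few. Any claim that something is new, unique, unknown or untested is made for them only; others in the source may bear on it.

Measured so far:
compound 1 `COc1ncnc2c1c(-c1ccoc1)cn2[C@@H]1O[C@H](CO)[C@@H](O)[C@H]1O`: 110 nM
compound 2 `C#Cc1cn([C@@H]2O[C@H](CO)[C@@H](O)[C@H]2O)c2ncnc(OC)c12`: 4060 nM
compound 3 `COc1nc(N)nc2c1c(-c1ccco1)cn2[C@@H]1O[C@H](CO)[C@@H](O)[C@H]1O`: > 20000 nM

Values come from a functional assay on HCT-116 cells (Homo sapiens), read by MTT assay, with a stated time of 72 h; on this read-out lower numbers stand for stronger inhibition and higher numbers for weaker inhibition. Compound 1, with furan-3-yl, gives 110 nM in this assay. Compound 2 gives 4060 nM, so the move a 37-fold higher number from compound 1 to compound 2 (1.57 log units; beyond the scatter). For compound 3 this assay reports only a limit, > 20000 nM; the value sits at the limit of > 20000 nM in this assay, at which 1 of the 3 values shown sits, and is not a number, so compound 3 stands at the weak end of what has been measured, with no reading of its own.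

Compound 4 `COc1ncnc2c1c(-c1ccco1)cn2[C@@H]1O[C@H](CO)[C@@H](O)[C@H]1O` is the unmeasured partner of compound 3: the change is hydrogen in place of amino on an aromatic carbon. Among the measured compounds shown here, no measured step covers this change. For the measured compounds named here, the one measured step, from compound 1 to compound 2, concerns a different position and does not bear on the amino group. What does bear on it is compound 1, which also carries a hydrogen at that position together with a furan group and gives 110 nM in this assay. Compound 3, by contrast, carries the amino group and reaches only a limit.

Compound 4 is therefore expected to give a number near that of compound 1, estimated at 150 nM (range 30 nM to 1500 nM). This estimate means an expected step of an at least 130-fold lower number from compound 3 to compound 4 (2.12 log units; beyond the scatter), a large fall from the limit of compound 3, in the direction of stronger inhibition.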

Compound 4, half-maximal inhibitory concentration: 40 nM
Compound 4: the middle estimate sits 3.8-fold (0.57 log units) above what was measured, and the stated range covers the measured number.
By their numbers in this assay, from the lowest: compound 4; then compound 1; then compound 2. At a limit, above all of these: compound 3.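

Compound 3 is held in this assay by a limit and not by a number: the limit of > 20000 nM in this assay, at which 1 of the 4 values shown sits.

Among the compounds shown here, with furan-2-yl held fixed, hydrogen in place of amino on this aromatic carbon, between two ring nitrogen atoms, gives an at least 500-fold lower number from compound 3 to compound 4 (2.69 log units; beyond the scatter), the first reading of this position and a large step for the loss of one heavy atom. The aromatic carbon carrying the furan also gains a clearer reading, since furan-2-yl in place of ethynyl gives a 100-fold lower number from compound 2 to compound 4 (2.01 log units; beyond the scatter), whereas furan-2-yl in place of furan-3-yl gives only a modest change, a 2.8-fold lower number from compound 1 to compound 4 (0.44 log units; beyond the scatter), so the choice between the two furans counts for far less here than the choice between a furan and ethynyl or between hydrogen and amino.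

The amino step is read only with furan-2-yl, so the compounds shown leave open whether it holds with furan-3-yl or ethynyl on the other carbon. They also leave open how this position would read with a group of intermediate size, such as methyl or a methylamino group, and so whether the step belongs to amino alone or to any group other than hydrogen.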